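Cytotoxicity of biaryl hexanoic acids: a nitrophenyl analogue

The source may report more compounds than this note shows. Statements on the series, on what has been measured and on what is new or still open speak of the compounds shown alone.

Compound 1 `CC(C)N(Cc1cccc(OCCCCCC(=O)O)c1)C(=O)c1ccc(-c2ccco2)cc1`: in an ADME assay on BJ cells (Homo sapiens) for cytotoxicity, read by CellTiter-Glo and resazurin assay, with a stated time of 72 h (on this read-out lower numbers stand for an effect already at smaller amounts and higher numbers for an effect only at larger amounts of compound), a limit, > 26000 nM.
Compound 2 `CC(C)Oc1cccc(-c2ccc(C(=O)N(Cc3cccc(OCCCCCC(=O)O)c3)C(C)C)cc2)c1`: in this assay a limit, > 26000 nM.
Compound 3 `COc1cc(F)cc(-c2ccc(C(=O)N(Cc3cccc(OCCCCCC(=O)O)c3)C(C)C)cc2)c1`: in this assay a limit, > 26000 nM.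

Compound 3 stands at the same limit as the two other measured compounds, so no ordering among the three can be read. Within the data shown here, the steps a step that the two limits leave unreadable from compound 1 to compound 3 and a step that the two limits leave unreadable from compound 2 to compound 3 are unreadable for this reason, and so is a step that the two limits leave unreadable from compound 1 to compound 2; the only evidence is the limit of > 26000 nM in this assay, at which 3 of the 3 values shown sit.

Compound 4 `CC(C)N(Cc1cccc(OCCCCCC(=O)O)c1)C(=O)c1ccc(-c2cccc([N+](=O)[O-])c2)cc1` differs from compound 3 by 3-nitrophenyl in place of 3-fluoro-5-methoxyphenyl on an aromatic carbon. Since every measured change of the group on this aromatic carbon, whether to furan-2-yl, 3-isopropoxyphenyl or 3-fluoro-5-methoxyphenyl, left the read-out at the limit, no step beyond the scatter is expected from this exchange either, and the most likely outcome is again a limit.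

Compound 4 is therefore estimated in this assay at about 30000 nM, with a plausible range from 12000 nM to 100000 nM. The estimated step is a step that the limit leaves unreadable from compound 3 to compound 4, which is expected to be indistinguishable from none.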

Compound 4, half-maximal effective concentration: > 26000 nM
Compound 4 ended at the assay's limit (the forecaster's own chance of this, stated with the estimate: 85%); the middle value does not contradict the limit.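

In this assay, among these compounds, compound 4 gives a limit, as do compound 1, compound 2 and compound 3, so no step among them can be read: the limit of > 26000 nM in this assay, at which 4 of the 4 values shown sit. The compounds shown leave open where their half-maximal effective concentrations lie and whether exchanging the group on this aromatic carbon changes them.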